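The compounds below may be only part of what the source reports. "The series", "measured", "known", "first", "only" and "open" are said of these compounds alone.

Compounds measured so far:
compound 1 `COc1cc(/C=C/C(=O)Nc2ccccc2)ccc1OCCCCN(C)C`, 1.57
compound 2 `COc1cc(/C=C/C(=O)Nc2ccccc2)ccc1OCCCCCCN(C)C`, 1.69

Compound 2 stands highest of the two numbers in a physicochemical assay for lipophilicity, using the shake flask method, measured as octanol-water partition, at pH 7.4 (on this read-out lower numbers stand for lower lipophilicity and higher numbers for higher lipophilicity), with compound 1 as its nearest neighbour; the step of a number 0.12 log units higher from compound 1 to compound 2 (within the scatter) lies within the scatter, so the two cannot be ordered. Compound 3 `COc1cc(/C=C/C(=O)Nc2ccccc2)ccc1OCCCCCCN1CCCC1` is not yet measured in this assay. It differs from compound 2 by pyrrolidin-1-yl in place of dimethylamino on a saturated chain carbon, six bonds along the chain from an oxygen on an aromatic ring. Among the compounds with values here, no measured step bears directly on this exchange: the one known step, a number 0.12 log units higher from compound 1 to compound 2 (within the scatter), concerns only the chain length and was within the scatter, so it offers no guide to swapping the amine itself. The estimate therefore rests on the step from compound 2 alone. Compound 3 is expected to give 2.1 in this assay, with a range from 1.7 to 2.5. That expectation corresponds to a step of a number 0.41 log units higher from compound 2 to compound 3 (beyond the scatter), a modest rise that may or may not clear the scatter.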

Compound 3, partition coefficient: 1.76
Compound 3: middle estimate off by 0.34 log units, on the high side; the range from low to high includes it.
By their numbers in this assay, from the lowest: compounds 1, 2 and 3 (each within the scatter of the next).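

In this assay, pyrrolidin-1-yl in place of dimethylamino on a saturated chain carbon, six bonds along the chain from an oxygen on an aromatic ring, gives a number 0.07 log units higher from compound 2 to compound 3 (within the scatter) and so cannot be told apart from no difference at this position. Within the data shown here, the earlier compounds varied only the chain, whereas this result is the first reading on the amine itself. Even with both differences taken together, as 2-(pyrrolidin-1-yl)ethyl in place of dimethylamino four bonds along the chain from that oxygen, the result is a number 0.19 log units higher from compound 1 to compound 3 (within the scatter) and no cause can be drawn from the data.

Going by these compounds, it remains open whether piperidin-1-yl, morpholin-4-yl or a longer chain would move the read-out beyond the scatter. Also open, on these data alone, is how pyrrolidin-1-yl behaves when it sits four bonds along the chain.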